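The compounds below may be only part of what the source reports. "The series", "measured", "known", "first", "only" and "open" are said of these compounds alone.

Measured in an assay on mitochondria (strain Sprague-Dawley) for inhibition of Amine oxidase [flavin-containing] B (Rattus norvegicus), read by fluorescence and Amplex Red, with stated times of 30 min and 45 min; on this read-out lower numbers stand for stronger inhibition and higher numbers for weaker inhibition:
compound 1 `COc1cccc(CCCC(=O)Nc2nc3ccccc3c(=O)s2)c1` gives 1300 nM
compound 2 `O=C(C/C=C/c1ccc(Cl)c(Cl)c1)Nc1nc2ccccc2c(=O)s1` gives 4640 nM
compound 3 `COc1cccc(/C=C/C(=O)Nc2nc3ccccc3c(=O)s2)c1` gives 281 nM

Among these three numbers compound 1 stands second highest: compound 2 lies nearest, with a higher number beyond the scatter, and compound 3 lies furthest, with a lower number beyond the scatter. Compound 4 `O=C(CCCc1ccc(Cl)c(Cl)c1)Nc1nc2ccccc2c(=O)s1` has not yet been measured in this assay. It differs from compound 1 in one place: 3,4-dichlorophenyl in place of 3-methoxyphenyl on a saturated chain carbon, three bonds along the chain from a carbonyl carbon. Going by the values given here, no measured pair isolates this swap on its own. Compound 2, which also carries the 3,4-dichlorophenyl but on a different chain, gives the highest number shown, 4640 nM, which points toward a weaker inhibitor. A modest upward step from compound 1 to compound 4 is therefore expected, a 1.9-fold higher number from compound 1 to compound 4 (0.28 log units; within the scatter), possibly no larger than the scatter. Compound 4 is estimated at 2500 nM, within 800 nM to 8000 nM.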

Compound 4, half-maximal inhibitory concentration: 3300 nM
Estimate against measurement, compound 4: 1.3-fold (0.12 log units) below, within the range that was stated.
By their numbers in this assay, from the lowest: compound 3; then compound 1; then compounds 4 and 2 (each within the scatter of the next).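

The swap of 3,4-dichlorophenyl for 3-methoxyphenyl, on a saturated chain carbon, three bonds along the chain from a carbonyl carbon, is now isolated in this assay as a 2.5-fold higher number from compound 1 to compound 4 (0.40 log units; beyond the scatter) on an otherwise unchanged molecule. The aryl group at this place therefore matters, and 3-methoxyphenyl goes with the stronger inhibition of the pair. No evidence at hand accounts for the step.

As far as these compounds go, it remains open how an unsubstituted phenyl or a pyridine would behave at this place. From the compounds shown here alone, whether the swap gives a similar step on the unsaturated chains also stays open, as compound 2 and compound 3 differ in more than one place.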